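A few compounds are considered here, and "the series" means these few. Any claim that something is new, unique, unknown or untested is made for them only; others in the source may bear on it.

Working notes on the series. In an assay on FRT cells for positive allosteric modulation of Cystic fibrosis transmembrane conductance regulator variant N1303K (Homo sapiens), in the presence of a further agent that is not named here (a lower number here means that less compound is needed, a higher number that more compound is needed for the effect), compound 1 `COc1ccc2[nH]c3c(c2c1)CCNC31CCN(Cc2ccc([N+](=O)[O-])cc2F)CC1` gives 5900 nM, compound 2 `COc1ccc2[nH]c3c(c2c1)CCNC31CCN(Cc2ccc(Cl)cc2Cl)CC1` gives 1800 nM, and compound 3 `COc1ccc2[nH]c3c(c2c1)CCNC31CCN(Cc2ccc(F)c(Cl)c2F)CC1` gives 4500 nM. Among these three numbers compound 3 stands second highest: its gap to compound 1 lies within the scatter, as a 1.3-fold lower number from compound 1 to compound 3 (0.12 log units; within the scatter) shows, while the step of a 2.5-fold higher number from compound 2 to compound 3 (0.40 log units; beyond the scatter) puts compound 2 beyond the scatter below it.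

The unmeasured compound 4 `COc1ccc2[nH]c3c(c2c1)CCNC31CCN(Cc2cccc(F)c2F)CC1` differs from compound 3 in one place: 2,3-difluorophenyl in place of 3-chloro-2,4-difluorophenyl on a saturated chain carbon bound to an amine nitrogen in a ring. Every measured step in the set exchanges the aryl group at this same place, and the largest of them, a 3.3-fold lower number from compound 1 to compound 2 (0.52 log units; beyond the scatter), remains modest. Exchanging one aryl for another has therefore shifted this assay by modest amounts at most, in either direction, and once not beyond the scatter. Within the data shown here, no measured pair shows loss of a chlorine with two fluorines kept, so no direction is indicated. The step from compound 3 to compound 4 is expected to stay within the scatter, a 1.1-fold higher number from compound 3 to compound 4 (0.05 log units; within the scatter). Compound 4 is estimated at 5000 nM in this assay, with a range from 2000 nM to 13000 nM.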

Compound 4, half-maximal effective concentration: 13600 nM
For compound 4 the middle estimate is 2.7-fold (0.43 log units) below the measured one, and the stated range ends below it.
By their numbers in this assay, from the lowest: compound 2; then compounds 3 and 1 (each within the scatter of the next); then compound 4.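

Among these compounds, at this place, the change to 2,3-difluorophenyl gives the first step that removes the chlorine while keeping two fluorines, and a 3.0-fold higher number from compound 3 to compound 4 (0.48 log units; beyond the scatter) lies beyond the scatter in this assay. Compound 4 also stands apart from the other two aryl groups: a 7.6-fold higher number from compound 2 to compound 4 (0.88 log units; beyond the scatter) is now the widest step at this place, and a 2.3-fold higher number from compound 1 to compound 4 (0.36 log units; beyond the scatter) also lies beyond the scatter. No accompanying data bear on why the number rises with this change.

The 3-chloro-2,4-difluorophenyl to 2,3-difluorophenyl change alters both the chlorine and the fluorine pattern, so the compounds shown do not separate these two contributions. As far as these compounds go, how a trifluoromethyl or methoxy group on the phenyl ring would read in this assay also remains open.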